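Working notes on the carbonyl substituent step to compound 3

The compounds below may be only part of what the source reports. "The series", "measured", "known", "first", "only" and "open" are said of these compounds alone.

Measured so far in a functional assay on HeLa cells (Homo sapiens) for cytotoxicity, read by MTT assay; a lower number here means a stronger inhibitor, a higher number a weaker inhibitor:
- compound 1 (`CCC(O)CO[C@H](CC=C(C)C)C1=CC(=O)c2c(O)ccc(O)c2C1=O`) gives 28700 nM
- compound 2 (`CC(C)=CC[C@@H](OC(=O)CC(O)c1ccccc1)C1=CC(=O)c2c(O)ccc(O)c2C1=O`) gives 44500 nM

Within the data shown here, compound 2 stands within the scatter of compound 1, the only other measured compound, and the two numbers give no ordering. The next case is compound 3 (`CC(C)=CC[C@@H](OC(=O)C1CCOC1)C1=CC(=O)c2c(O)ccc(O)c2C1=O`), still unmeasured. It carries oxolan-3-yl in place of 2-hydroxy-2-phenylethyl on a carbonyl carbon. The aromatic ring and the hydrogen-bond donor of the leaving group are gone, and the shared core stays as it is.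

Among the measured compounds shown here, no measured pair of compounds differs in one place, so nothing measured speaks directly to this exchange. The expectation rests only on compound 1 at 28700 nM and compound 2 at 44500 nM, which lie within the scatter of each other. No step beyond the scatter is expected in this assay, and no firm direction can be given. The expected change is a 1.5-fold lower number from compound 2 to compound 3 (0.17 log units; within the scatter) and is only a rough estimate. The estimate for compound 3 is 30000 nM ( expected range 9000 nM to 80000 nM).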

Compound 3, half-maximal inhibitory concentration: 73500 nM
Compound 3: the middle estimate sits 2.5-fold (0.39 log units) below what was measured; measured number inside the range.
By their numbers in this assay, from the lowest: compounds 1, 2 and 3 (each within the scatter of the next, the first and the last beyond it).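

In this assay, oxolan-3-yl in place of 2-hydroxy-2-phenylethyl on a carbonyl carbon gives a 1.7-fold higher number from compound 2 to compound 3 (0.22 log units; within the scatter) and so does not separate the two compounds, even though the six-membered aromatic ring and the hydrogen-bond donor of the leaving group are both gone. The series now also has its first step beyond the scatter, though only a modest one: (oxolan-3-yl)carbonyl in place of 2-hydroxybutyl on an oxygen on a saturated carbon gives a 2.6-fold higher number from compound 1 to compound 3 (0.41 log units; beyond the scatter) and leaves compound 3 as the weaker of that pair. No measurement at hand offers an explanation for either step.

The compounds shown do not separate the aromatic ring from the hydroxyl of 2-hydroxy-2-phenylethyl, as both leave in the same single step. Also open, on these data alone, is where a benzyl group, which keeps the ring without the hydroxyl, or a longer chain ending in an amine would stand on the same carbonyl carbon, and whether either would give a step beyond the scatter from compound 2.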